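Nitro to chloro on the pyrazoline series: cytotoxicity notes

A few compounds are considered here, and "the series" means these few. Any claim that something is new, unique, unknown or untested is made for them only; others in the source may bear on it.

Measured compounds:
- compound 1, `CC(=O)N1N=C(c2ccccc2)CC1c1cccc(Cl)c1Cl`: 24000 nM
- compound 2, `CC(=O)N1N=C(c2ccco2)CC1c1ccc([N+](=O)[O-])cc1`: 21800 nM

In a functional assay on HEp-2 cells (Homo sapiens) for cytotoxicity, read by sulforhodamine B assay, with a stated time of 48 h (a higher number here means a weaker inhibitor, a lower number a stronger inhibitor), compound 1 gives 24000 nM and compound 2 gives 21800 nM. Compound 2 shows the lowest of the two numbers, but the gap to compound 1 lies within the scatter, so the two compounds cannot be separated on these values.

Compound 3, `CC(=O)N1N=C(c2ccco2)CC1c1ccc(Cl)cc1`, has not yet been measured in this assay. It differs from compound 2 by chloro in place of nitro on an aromatic carbon. Going by the values given here, no pair of measured compounds isolates this change, so no step of known size can be drawn on. With both measured compounds sitting close together, the step from compound 2 to compound 3 is expected to stay within the scatter, as a 1.1-fold higher number from compound 2 to compound 3 (0.06 log units; within the scatter). Compound 3 is accordingly estimated at 25000 nM, with a range from 8000 nM to 80000 nM.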

Compound 3, half-maximal inhibitory concentration: 57400 nM
Compound 3: middle estimate off by 2.3-fold (0.36 log units), on the low side, within the range that was stated.
By their numbers in this assay, from the lowest: compounds 2 and 1 (each within the scatter of the next); then compound 3.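

In this assay, going by these compounds alone, chloro in place of nitro on an aromatic carbon gives a 2.6-fold higher number from compound 2 to compound 3 (0.42 log units; beyond the scatter), the first change that can be read in one place. The read-out therefore responds to what sits on this six-membered aromatic ring, para to a large group, which compound 1 and compound 2 could not show because they differ in more than one place. Nothing measured on these groups accounts for the step, so its origin stays unassigned.

As far as these compounds go, it remains open whether other groups at this carbon, such as an amine, a methoxy group or a carboxylic acid, would fall near nitro or near chloro. From the compounds shown here alone, it is also open whether the same exchange gives a step of similar size on another core, such as the core of compound 1.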